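Hydroxy for Tert-Butyl in a Paw Edema Series

The compounds below may be only part of what the source reports. "The series", "measured", "known", "first", "only" and "open" are said of these compounds alone.

Of the compounds shown here, three sharing one core have been tested in a functional assay on the whole organism for inhibition, with Rattus norvegicus as the target, read by paw edema, with stated times of 1 h and 3 h, at a dose of 50 mg/kg by the oral route; a higher number here means more inhibition at the dose given (going by the name of the read-out), a lower number less inhibition. Compound 1 `C/C(=N\OCC(=O)O)c1ccccc1Cl` gives < 20%, which is a limit of the assay and not a number. Compound 2 `C/C(=N\OCC(=O)O)c1ccccc1C(=O)O` likewise gives < 20%, again a limit. The step that the two limits leave unreadable from compound 1 to compound 2 is unreadable, both of its ends being limits. Compound 3 `C/C(=N\OCC(=O)O)c1ccc(C(C)(C)C)cc1` stands at < 20%, also a limit; it is one of the values covered by the limit of < 20% in this assay, at which 3 of the 3 values shown sit, so nothing separates it from the other two compounds.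

Compound 4 `C/C(=N\OCC(=O)O)c1ccc(O)cc1` differs from compound 3 in one place: hydroxy in place of tert-butyl on an aromatic carbon. No measured step bears on this change: the only step shown, from compound 1 to compound 2, is unreadable, and no step starting from compound 3 has been measured. Nothing among the three values points away from the limit, so the expected step is none beyond the scatter, a step that the limit leaves unreadable from compound 3 to compound 4. Compound 4 is therefore estimated at 12%, with a range from 0% to 30%, and most likely the assay will again report only a limit.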

Compound 4, a percentage reported as inhibition, in the whole organism at one dose (the size of the read-out at that dose, not a potency): < 20%
Compound 4: only a limit was reported; the forecaster's own chance of this, stated with the estimate: 70%; the middle value lies beyond the limit too.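

Compound 3 and compound 4 each give only a limit of the assay and not a number, so no size can be read for hydroxy in place of tert-butyl: the limit of < 20% in this assay, at which 4 of the 4 values shown sit.

The compounds shown leave open whether any group on the shared core gives a readable number in this assay and how such groups would compare.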